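Shifting the side chain on the core: compound 1 to compound 4

The source may report more compounds than this note shows. Statements on the series, on what has been measured and on what is new or still open speak of the compounds shown alone.

Three measured compounds share one core, differing only in the group on the aromatic nitrogen. Compound 1 `CN1CCN(CCCCCn2c3c(c4ccccc42)C(=O)c2c[n+]([O-])c4ccccc4c2C3=O)CC1` carries a basic chain; compound 2 `O=C1c2c[n+]([O-])c3ccccc3c2C(=O)c2c1c1ccccc1n2Cc1cn([C@H]2O[C@H](CO)[C@@H](O)[C@H]2O)nn1` and compound 3 `O=C1c2c[n+]([O-])c3ccccc3c2C(=O)c2c1c1ccccc1n2Cc1cn([C@@H]2O[C@H](CO)[C@@H](O)[C@H](O)[C@H]2O)nn1` carry sugar-bearing triazoles. In a functional assay on MDA-MB-231 cells (Homo sapiens) for cytotoxicity, read by MTT assay, with a stated time of 72 h (on this read-out lower numbers stand for stronger inhibition and higher numbers for weaker inhibition), compound 1 gives 2270 nM, compound 2 gives 1700 nM and compound 3 gives 650 nM. Compound 1 thus returns the highest of the three numbers, though its gap to compound 2 lies within the scatter, while its gap to compound 3 lies beyond it.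

Compound 4 `O=C1c2c[n+]([O-])c3ccccc3c2C(=O)c2c1c1ccccc1n2CCCN1CCC(O)CC1` differs from compound 1 as follows: 4-hydroxypiperidin-1-yl in place of 2-(4-methylpiperazin-1-yl)ethyl on a saturated chain carbon, three bonds along the chain from an aromatic nitrogen.

Going by the values given here, the only measured step, a 2.6-fold lower number from compound 2 to compound 3 (0.42 log units; beyond the scatter), concerns a change of sugar on a triazole and does not bear on a basic side chain. Among the compounds with values here, no measured pair therefore informs this change; the chain is shortened and its terminal ring is altered without precedent.

Compound 4 is accordingly expected to stay near compound 1, the step of a 1.1-fold lower number from compound 1 to compound 4 (0.05 log units; within the scatter) being estimated as none beyond the scatter. The estimate for compound 4 is 2000 nM, with a range from 900 nM to 4500 nM.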

Compound 4, half-maximal inhibitory concentration: 280 nM
Estimate against measurement, compound 4: 7.1-fold (0.85 log units) above, and the stated range ends above it.
By their numbers in this assay, from the lowest: compound 4; then compound 3; then compounds 2 and 1 (each within the scatter of the next).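

In this assay, exchanging the 5-(4-methylpiperazin-1-yl)pentyl group on the aromatic nitrogen for 3-(4-hydroxypiperidin-1-yl)propyl gives an 8.1-fold lower number from compound 1 to compound 4 (0.91 log units; beyond the scatter), a larger step than the sugar exchange, a 2.6-fold lower number from compound 2 to compound 3 (0.42 log units; beyond the scatter). An amine-ended chain at this position can therefore give a lower number than a sugar-bearing triazole: compound 4 reads 280 nM and compound 3 reads 650 nM. No supporting measurement accounts for the step.

Chain length and terminal ring change together here, so the step cannot be assigned to either alone; 3-(4-methylpiperazin-1-yl)propyl and 5-(4-hydroxypiperidin-1-yl)pentyl on the shared core would separate the two. Also open, going by these compounds, is how the propyl chain reads with another terminal ring, such as morpholin-4-yl or 4-aminopiperidin-1-yl.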